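Notes on the cinnamic acid series: compound 3 to compound 4

A few compounds are considered here, and "the series" means these few. Any claim that something is new, unique, unknown or untested is made for them only; others in the source may bear on it.

Measured so far in a functional assay on MCF7 cells (Homo sapiens) for cytotoxicity, read by CellTiter-Glo, with a stated time of 5 days; a higher number here means a weaker inhibitor, a lower number a stronger inhibitor:
- compound 1 `O=C(O)/C=C/c1ccc(/C(=C(\c2ccccc2)C2CCCCC2)c2ccc3[nH]ncc3c2)cc1`: 64 nM
- compound 2 `O=C(O)/C=C/c1ccc(/C(=C(\c2ccc(F)cc2Cl)C2CCC2)c2ccc3[nH]nc(F)c3c2)cc1`: 2 nM
- compound 3 `CS(=O)(=O)c1ccc(/C(=C(\c2ccc(/C=C/C(=O)O)cc2)c2ccc3[nH]nc(F)c3c2)C2CCC2)c(Cl)c1`: 2.3 nM

Compound 3 stands second highest of the three numbers. Its nearest neighbour is compound 2; the step of a 1.2-fold higher number from compound 2 to compound 3 (0.06 log units; within the scatter) shows that exchanging one aromatic substituent for another at that place leaves the number within the scatter. The furthest is compound 1, whose value in this assay lies beyond the scatter from that of compound 3; compound 1 differs from compound 3 in several places at once, so no single cause can be read from the pair.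

Compound 4 `O=C(O)/C=C/c1ccc(/C(=C(\c2ccccn2)C2CCC2)c2ccc3[nH]nc(F)c3c2)cc1` is not yet measured. It differs from compound 3 by pyridin-2-yl in place of 2-chloro-4-(methylsulfonyl)phenyl on a double-bonded chain carbon bound to a double-bonded chain carbon and a saturated ring carbon. Among the compounds with values here, no measured pair covers this exchange: the only step on that aryl group, from compound 2 to compound 3, swaps one substituent and stays within the scatter, while the chlorine is kept in both. Compound 4 loses both substituents and gains a ring nitrogen, a larger change than any measured. A modest rise in the number is therefore expected, a 2.6-fold higher number from compound 3 to compound 4 (0.42 log units; beyond the scatter), with wide uncertainty.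

For compound 4 the expected value in this assay is 6 nM, within 2 nM to 20 nM.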

Compound 4, half-maximal inhibitory concentration: 22 nM
Estimate against measurement, compound 4: 3.7-fold (0.56 log units) below; the measured number lies above the stated range.
By their numbers in this assay, from the lowest: compounds 2 and 3 (each within the scatter of the next); then compound 4; then compound 1.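

In this assay the aryl group on this double-bonded chain carbon turns out to matter: the step of a 1.2-fold higher number from compound 2 to compound 3 (0.06 log units; within the scatter) swapped only one substituent, whereas replacing the whole group gives a 9.6-fold higher number from compound 3 to compound 4 (0.98 log units; beyond the scatter) and an 11-fold higher number from compound 2 to compound 4 (1.04 log units; beyond the scatter). Both of these steps lie beyond the scatter, so the low numbers hold with either fluoro or methylsulfonyl on the chlorinated phenyl ring, but they are not kept with pyridin-2-yl in these compounds. Nothing available here gives a reason for the rise.

Each of the two new steps combines the loss of the chlorine, the loss of the second substituent and the gain of a ring nitrogen, so the compounds shown cannot divide the rise among these three changes. A 2-chlorophenyl group would separate the ring nitrogen from the substituents, and a pyridin-2-yl ring carrying a chlorine or an amine would show whether a substituted pyridine can return to the range of compound 2 and compound 3.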